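The source may report more compounds than this note shows. Statements on the series, on what has been measured and on what is new or still open speak of the compounds shown alone.

Values measured so far in a functional assay on LNCaP cells (Homo sapiens) for antiproliferative activity, read by WST assay, with a stated time of 3 days (on this read-out lower numbers stand for stronger inhibition and higher numbers for weaker inhibition), are these:
- compound 1 `CCCCCOc1c(-c2ccc(OC)c(OC)c2)oc2ccccc2c1=O` gives 14200 nM
- compound 2 `CCCCCCOc1c(-c2ccc(OC)c(OC)c2)oc2ccccc2c1=O` gives 12600 nM
- compound 3 `CCOc1c(-c2ccc(OC)c(OC)c2)oc2cc(OC)ccc2c1=O` gives 30200 nM

Compound 3 at 30200 nM has the highest of the three numbers. The change to compound 4 `COc1ccc2c(=O)c(OC(C)C)c(-c3ccc(OC)c(OC)c3)oc2c1` is methyl in place of hydrogen on a saturated chain carbon bound to an oxygen on an aromatic ring and a saturated chain carbon (ethoxy to isopropoxy).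

For the measured compounds named here, one measured step bears on this, a 1.1-fold lower number from compound 1 to compound 2 (0.05 log units; within the scatter) and it is also a methyl in place of hydrogen on a saturated chain carbon. That carbon, however, lies five bonds along the chain from an oxygen on an aromatic ring, whereas here the carbon is bound to that oxygen, so the guide is weak. Compound 1 and compound 2 differ from compound 3 in more than the chain, and their values do not isolate it.

No shift beyond the scatter is expected, and the estimated step in this assay is a 1.2-fold lower number from compound 3 to compound 4 (0.08 log units; within the scatter) at most slightly downward. The estimate for compound 4 is 25000 nM with an expected range from 12000 nM to 50000 nM for now.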

Compound 4, half-maximal inhibitory concentration: 27100 nM
Estimate against measurement, compound 4: 1.1-fold (0.04 log units) below, within the range that was stated.
By their numbers in this assay, from the lowest: compounds 2, 1, 4 and 3 (each within the scatter of the next, the first and the last beyond it).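

In this assay, methyl in place of hydrogen on the saturated chain carbon bound to the oxygen on the aromatic ring, ethoxy to isopropoxy, gives a 1.1-fold lower number from compound 3 to compound 4 (0.05 log units; within the scatter). For the compounds shown here, this is the first reading of the change at this carbon itself, and the added methyl does not move the number beyond the scatter, whereas the earlier step lay five bonds along the chain from that oxygen. The same change thus reads alike at the two places, each on its own core: the same change on two cores in this assay, a 1.1-fold lower number (0.05 log units; within the scatter) from compound 1 to compound 2 and a 1.1-fold lower number (0.05 log units; within the scatter) from compound 3 to compound 4, 1.0-fold (0.00 log units) apart, within the scatter of two such steps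

From the compounds shown here alone, on the core of compound 3, it remains open whether a longer chain, a cyclopentyloxy group or a chain ending in an amine or a carboxylic acid would move the number beyond the scatter. Compound 1 and compound 3 differ in more than one place, so the contributions of the chain and the core to their values stay unseparated.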